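This account rests on a few compounds, and the source may have more. Where it says the series, first, only, none or still open, it means among the compounds named here.

Measured so far in a functional assay on MCF7 cells (Homo sapiens) for cytotoxicity, read by MTT assay, with a stated time of 48 h; a higher number here means a weaker inhibitor, a lower number a stronger inhibitor:
compound 1 `Cc1ccc(S(=O)(=O)/N=C(/CCNC2=CC(=O)c3ccccc3C2=O)Nc2cccc(C)c2)cc1`, 8120 nM
compound 2 `Cc1ccc(S(=O)(=O)/N=C(/CCNC2=CC(=O)c3ccccc3C2=O)Nc2cccc(C(F)(F)F)c2)cc1`, 89100 nM

Among the measured compounds shown here, compound 1 holds the lowest of the two numbers in this assay; its only neighbour is compound 2, reached by the step of an 11-fold higher number from compound 1 to compound 2 (1.04 log units; beyond the scatter).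

Compound 3 `Cc1ccc(S(=O)(=O)/N=C(\N)CCNC2=CC(=O)c3ccccc3C2=O)cc1` differs from compound 1 as follows: hydrogen in place of 3-methylphenyl on an amine nitrogen. For the measured compounds named here, no measured step removes this group; the single step known touches only a substituent on that same 3-methylphenyl, and it was large. A step beyond the scatter is therefore expected in this assay, most likely towards a higher number, though the direction is uncertain. For compound 3 the expected value is 30000 nM, within 8000 nM to 150000 nM. The expected step is a 3.7-fold higher number from compound 1 to compound 3 (0.57 log units; beyond the scatter).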

Compound 3, half-maximal inhibitory concentration: 18600 nM
Compound 3: the middle estimate sits 1.6-fold (0.21 log units) above what was measured; measured number inside the range.
By their numbers in this assay, from the lowest: compound 1; then compound 3; then compound 2.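

In this assay, the aryl group on the amine nitrogen can be lost without a large change: replacing 3-methylphenyl with hydrogen gives a 2.3-fold higher number from compound 1 to compound 3 (0.36 log units; beyond the scatter). Replacing 3-(trifluoromethyl)phenyl with hydrogen gives a 4.8-fold lower number from compound 2 to compound 3 (0.68 log units; beyond the scatter), so the sign of the aryl group's contribution depends on its substituent in these compounds. No measurement here accounts for either step.

The compounds shown leave open where an unsubstituted phenyl or a methyl group on that nitrogen would fall. They also leave open whether a methoxy group on the phenyl ring would follow methyl or trifluoromethyl.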